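The source may report more compounds than this note shows. Statements on the series, on what has been measured and on what is new or still open speak of the compounds shown alone.

Measured compounds in an assay on isolated protein for inhibition of ribosomal protein S6 kinase alpha-2 (Homo sapiens), with a stated time of 150 min; on this read-out lower numbers stand for stronger inhibition and higher numbers for weaker inhibition:
compound 1 `COc1cc(Nc2nc3cccc(-c4c(F)cccc4OC)c3o2)cc(OC)c1OC` gives 20 nM;
compound 2 `COc1cccc(F)c1-c1cccc2nc(Nc3cccc(S(N)(=O)=O)c3)oc12` gives 340 nM.

Among these two numbers, compound 1 stands lowest; its nearest neighbour is compound 2, whose number is higher by a margin that lies beyond the usual scatter. For the measured compounds named here, no step between compounds that differ in only one place is available, so nothing measured tells how a single change on the shared core shifts this read-out. Compound 3 `COc1cc(Nc2nc3cccc(-c4ccccc4-c4cn[nH]c4)c3o2)cc(OC)c1OC` is not yet measured. It differs from compound 1 in one place: a group of 11 heavy atoms (9 carbon, 2 nitrogen; one five-membered aromatic ring with 2 hetero atoms, one six-membered aromatic ring of carbon only) in place of a group of 9 heavy atoms (7 carbon, 1 oxygen, 1 fluorine; one six-membered aromatic ring of carbon only), on an aromatic carbon. The group that enters keeps one six-membered aromatic ring of carbon only and adds a five-membered aromatic ring with 2 hetero atoms bearing 1 hydrogen-bond donor, while the fluorine and the oxygen of the leaving group are gone. Going by the values given here, with no comparable step in hand, the expected step is of modest size, most likely towards a higher number, and the estimated step is a 2.0-fold higher number from compound 1 to compound 3 (0.30 log units; within the scatter). Compound 3 is therefore expected to give about 40 nM, within a range from 8 nM to 200 nM.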

Compound 3, half-maximal inhibitory concentration: 9300 nM
For compound 3 the middle estimate is 230-fold (2.37 log units) below the measured one; the measured number lies above the stated range.
By their numbers in this assay, from the lowest: compound 1; then compound 2; then compound 3.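

In this assay, for the compounds shown here, replacing the 2-fluoro-6-methoxyphenyl group on this aromatic carbon with the entering group gives a 470-fold higher number from compound 1 to compound 3 (2.67 log units; beyond the scatter) and so shows that this position, which the earlier compounds could not address, is far from indifferent to what it carries. The change is a single swap, yet several things happen together: the fluorine and the oxygen leave, while a five-membered aromatic ring with 2 hetero atoms and a hydrogen-bond donor enter. No measurement accompanying this result bears on why the number rises so far.

The compounds shown leave open which of these features accounts for the step. On these data alone, an unsubstituted phenyl, a 2-methoxyphenyl or a 2-fluorophenyl group on the same carbon would help separate them, and how far such groups would shift this read-out remains unknown.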